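The source may report more compounds than this note shows. Statements on the series, on what has been measured and on what is new or still open speak of the compounds shown alone.

Measured so far:
compound 1 `O=C(NCCCCN1CCN(c2ccc(O)cc2)CC1)c1ccc(-c2ccsc2)cc1`: 0.19 h
compound 2 `N#Cc1ccccc1N1CCN(CCCCNC(=O)c2ccc(-c3ccsc3)cc2)CC1`: 0.0333 h

In an ADME assay on microsomes from liver (Rattus norvegicus) for metabolic stability, read by LC-MS, using NADPH (on this read-out lower numbers stand for a shorter-lived compound and higher numbers for a longer-lived compound), compound 2 gives the lower of the two numbers, and compound 1 stands above it; the step of a 5.7-fold lower number from compound 1 to compound 2 (0.76 log units; beyond the scatter) is the only one in hand. Compound 3 `O=C(NCCCCN1CCN(c2ccccc2C(F)(F)F)CC1)c1ccc(-c2ccsc2)cc1` differs from compound 2 by trifluoromethyl in place of cyano on an aromatic carbon. Among the measured compounds shown here, no measured step exchanges one group for another on that ring; the one available step, a 5.7-fold lower number from compound 1 to compound 2 (0.76 log units; beyond the scatter), swaps the whole aryl group and so bears only loosely on the present change. It does show that alterations on this ring can move the read-out well beyond the scatter. For the measured compounds named here, with no closer precedent, the expected step for compound 3 is a 1.5-fold higher number from compound 2 to compound 3 (0.18 log units; within the scatter), small and of uncertain direction. The estimate for compound 3 is therefore 0.05 h, with an expected range from 0.02 h to 0.15 h.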

Compound 3, half-life: 0.0667 h
The estimate for compound 3 lay 1.3-fold (0.13 log units) below the measured number; the measured number falls inside the stated range.
By their numbers in this assay, from the lowest: compounds 2 and 3 (each within the scatter of the next); then compound 1.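

In this assay trifluoromethyl in place of cyano on an aromatic carbon, ortho to a large group, gives a 2.0-fold higher number from compound 2 to compound 3 (0.30 log units; within the scatter) and so does not separate these two groups at this position. The 2-(trifluoromethyl)phenyl group also stands apart from 4-hydroxyphenyl, with a 2.8-fold lower number from compound 1 to compound 3 (0.45 log units; beyond the scatter) and beyond the scatter, so compound 1 is separated from both compound 2 and compound 3 on this read-out. No measurement available here bears on the reason for either step.

Each step from compound 1 swaps the whole aryl group, which leaves open whether the separation follows the hydroxyl group or the place of the substituent. An unsubstituted phenyl on the same amine nitrogen, or a methoxy group or an amine on the same aromatic carbon, could show how far this read-out moves at this position.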